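This account rests on a few compounds, and the source may have more. Where it says the series, first, only, none or still open, it means among the compounds named here.

Working notes on the series. Compound 1 `C=C(Br)C(=O)Nc1ccc(C(=O)/C=C/c2cccc(OC)c2)cc1` and compound 2 `C=C(Br)C(=O)Nc1ccc(C(=O)/C=C/c2ccc(OC)c(OC)c2)cc1` share one core; compound 3 `COc1ccccc1/C=C/C(=O)c1ccc(N)cc1` and compound 4 `COc1ccc(/C=C/C(=O)c2ccc(N)cc2)c(OC)c1` share a second core, and the difference between the two cores is not broken down here. In a functional assay on MOLT-4 cells (Homo sapiens) for antiproliferative activity, with a stated time of 48 h (a higher number here means a weaker inhibitor, a lower number a stronger inhibitor), compound 1 gives 1100 nM, compound 2 gives 1800 nM and compound 3 gives 8300 nM. The change methoxy in place of hydrogen on an aromatic carbon produced a 1.6-fold higher number from compound 1 to compound 2 (0.21 log units; within the scatter). The change methoxy in place of hydrogen on an aromatic carbon is the same kind of change, though the entering methoxy stands meta to a methoxy group rather than ortho to one. The step of a 1.1-fold higher number from compound 3 to compound 4 (0.06 log units; within the scatter) is expected to be small because the earlier step of a 1.6-fold higher number from compound 1 to compound 2 (0.21 log units; within the scatter) stayed within the scatter. Compound 4 is therefore expected to give about 9500 nM in this assay, with a range from 4000 nM to 25000 nM.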

Compound 4, half-maximal inhibitory concentration: 20000 nM
The estimate for compound 4 lay 2.1-fold (0.32 log units) below the measured number; the range from low to high includes it.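

In this assay, methoxy in place of hydrogen on the core of compound 3 gives a 2.4-fold higher number from compound 3 to compound 4 (0.38 log units; beyond the scatter), a step beyond the scatter, whereas the earlier step on the core of compound 1 stayed within it. Even so, the two steps cannot be told apart, so in these two pairs the change carries from one core to the other without a measurable difference in size: the same change on two cores in this assay, a 1.6-fold higher number (0.21 log units; within the scatter) from compound 1 to compound 2 and a 2.4-fold higher number (0.38 log units; beyond the scatter) from compound 3 to compound 4, 1.5-fold (0.17 log units) apart, within the scatter of two such steps. This rests on a single pair per core, with the entering methoxy placed differently in each, and does not show that the step holds on other cores or at other places on the ring.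

The compounds shown leave open whether a hydroxy group or an ethoxy group in the same place would behave as methoxy does. They also leave open what the step would be on the core of compound 1 with the entering methoxy meta to a methoxy group.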